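A Methyl Added to a Non-Cytotoxic Compound

The source may report more compounds than this note shows. Statements on the series, on what has been measured and on what is new or still open speak of the compounds shown alone.

In a functional assay on HeLa cells (Homo sapiens) for cytotoxicity, read by MTT assay, with a stated time of 24 h (on this read-out lower numbers stand for stronger inhibition and higher numbers for weaker inhibition), compound 1 (`Cc1cc2ccccc2nc1-c1cn(-c2ccc(F)cc2)nn1`) gives > 100 ug/mL, which is a limit of the assay and not a number. Compound 2 (`CCCCCCCCCCn1cc(-c2nc3ccccc3cc2CCC)nn1`), which carries a decyl chain, also gives only a limit, > 100 ug/mL. Going by the values given here, no measured step between compounds is available, so the data offer no direct guide to the size of a structural effect.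

Compound 3 (`CCc1cc2ccccc2nc1-c1cn(-c2ccc(F)cc2)nn1`) differs from compound 1 in one place: methyl in place of hydrogen on a saturated chain carbon bound to an aromatic carbon. This puts methyl in place of hydrogen on a saturated chain carbon bound to an aromatic carbon, a change of methyl to ethyl.

In this assay, no change beyond the scatter is expected, and neither direction is favoured. The expected step of a number no higher from compound 1 to compound 3 (the limit leaves the size open) is small because of the limit of > 100 ug/mL in this assay, at which 2 of the 2 values shown sit. Compound 3 will most likely also be reported only as a limit. Should a number be obtained, the estimate for compound 3 is 100 ug/mL, with an expected range from 50 ug/mL to 150 ug/mL.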

Compound 3, half-maximal inhibitory concentration: > 100 ug/mL
Compound 3 was reported as a limit (the forecaster's own chance of this, stated with the estimate: 85%); the middle value sits exactly at the limit.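

No step from compound 1 to compound 3 can be read in this assay, because each of the two compounds is reported only as a limit of the assay and not as a number: the limit of > 100 ug/mL in this assay, at which 3 of the 3 values shown sit.

The compounds shown leave open what size of effect, if any, methyl in place of hydrogen at this place has on the read-out.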